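This account rests on a few compounds, and the source may have more. Where it says the series, first, only, none or still open, it means among the compounds named here.

- Compound 1 `C/C(=N\NC(=O)COc1cccc2ccccc12)c1cccc([N+](=O)[O-])c1`: 3.37
- Compound 2 `C/C(=N\NC(=O)COc1cccc2ccccc12)c1ccccc1Br`: 4.44
- Compound 3 `C/C(=N\NC(=O)COc1cccc2ccccc12)c1ccc(Cl)cc1`: 4.17

These values come from a physicochemical assay for lipophilicity, measured as octanol-water partition; a higher number here means a more lipophilic compound, a lower number a more polar compound. The three compounds share one core and differ only in the phenyl group on a carbon with a double bond to nitrogen. Compound 3 sits level with compound 2, as the step of a number 0.27 log units lower from compound 2 to compound 3 (within the scatter) shows, and clearly clear of compound 1, as the step of a number 0.80 log units higher from compound 1 to compound 3 (beyond the scatter) shows.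

Compound 4 `C/C(=N\NC(=O)COc1cccc2ccccc12)c1ccc(O)cc1` carries hydroxy in place of chloro on an aromatic carbon, para to a large group: hydroxy in place of chloro on an aromatic carbon. The entering hydroxy is a hydrogen-bond donor and acceptor, and the leaving chloro is neither.

Among the measured compounds shown here, no measured step brings in hydroxy, so the data offer no direct guide. They show only how far a swap of this phenyl group has moved the number: the step of a number 1.07 log units higher from compound 1 to compound 2 (beyond the scatter) is the largest, and the step of a number 0.27 log units lower from compound 2 to compound 3 (within the scatter) stays within the scatter. Taking the step of a number 0.80 log units higher from compound 1 to compound 3 (beyond the scatter) as a guide to size, a fall of similar or somewhat greater size is expected in this assay. The expected step is a number 1.12 log units lower from compound 3 to compound 4 (beyond the scatter). The estimate for compound 4 is 3.05, with an expected range from 2.55 to 3.55.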

Compound 4, partition coefficient: 4.44
The estimate for compound 4 lay 1.39 log units below the measured number; the measured number lies above the stated range.
By their numbers in this assay, from the lowest: compound 1; then compounds 3, 2 and 4 (each within the scatter of the next).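

In this assay, hydroxy in place of chloro on this aromatic carbon, para to a large group, leaves the number level (a number 0.27 log units higher from compound 3 to compound 4 (within the scatter)), so bringing a hydrogen-bond donor and acceptor to this place produced no fall beyond the scatter in this pair. The 4-hydroxyphenyl group also stands level with 2-bromophenyl (no change at the digits printed from compound 2 to compound 4 (within the scatter)) and clear of 3-nitrophenyl (a number 1.07 log units higher from compound 1 to compound 4 (beyond the scatter)), which leaves compound 1 as the only one of the four set apart from the rest, while compounds 2, 3 and 4 form one group within the scatter. Nothing measured here accounts for hydroxy matching chloro at this place, so the result stands as an observation without an explanation.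

The compounds shown leave open whether this level reading extends to other groups at the same place, such as an amine, a methoxy group or a carboxylic acid. They also leave open whether hydroxy would give a similar number elsewhere on this phenyl ring, or on a phenyl ring that carries a second group.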